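The source may report more compounds than this note shows. Statements on the series, on what has been measured and on what is new or still open speak of the compounds shown alone.

Compound 1 `Cc1cn(C[C@H]2CN(c3ccc(C4=CCS(=O)(=O)CC4)c(F)c3)C(=O)O2)nn1`, in an assay for binding affinity to Amine oxidase [flavin-containing] A (Homo sapiens); on this read-out higher numbers stand for weaker inhibition and lower numbers for stronger inhibition: 25000 nM
Compound 2 `C[Si](C)(C)C#Cc1cn(C[C@H]2CN(c3ccc(C4=CCS(=O)(=O)CC4)c(F)c3)C(=O)O2)nn1`, this assay: > 200000 nM, a limit of the assay
Compound 3 `C#Cc1cn(C[C@H]2CN(c3ccc(C4=CCS(=O)(=O)CC4)c(F)c3)C(=O)O2)nn1`, this assay: > 200000 nM, a limit of the assay

Compound 2 stands at the limit of > 200000 nM in this assay, at which 2 of the 3 values shown sit, so only a limit and no number is known for it. Compound 4 `O=C1O[C@@H](Cn2cc(Br)nn2)CN1c1ccc(C2=CCS(=O)(=O)CC2)c(F)c1` differs from it by one bromine atom in place of a group of 6 heavy atoms (5 carbon, 1 silicon; no ring), on an aromatic carbon. The step of an at least 8.0-fold higher number from compound 1 to compound 2 (0.90 log units; beyond the scatter) shows that replacing methyl with the silyl-alkyne group pushed the number beyond the scatter, while a step that the two limits leave unreadable from compound 2 to compound 3 cannot be read from two limits. Bromo is a single atom, closer in size to the methyl of compound 1 than to the group it replaces, so compound 4 is expected to move back toward compound 1, a step of an at least 4.0-fold lower number from compound 2 to compound 4 (0.60 log units; beyond the scatter). Compound 4 is therefore estimated at 50000 nM, within 15000 nM to 200000 nM.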

Compound 4, inhibition constant: 16000 nM
For compound 4 the middle estimate is 3.1-fold (0.49 log units) above the measured one; low and high end bracket the measured number.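

At this position on the five-membered aromatic ring, bromo gives a readable number in this assay, with an at least 12-fold lower number from compound 2 to compound 4 (1.09 log units; beyond the scatter) and an at least 12-fold lower number from compound 3 to compound 4 (1.09 log units; beyond the scatter). Bromo in place of methyl gives a 1.6-fold lower number from compound 1 to compound 4 (0.19 log units; within the scatter), so the two substituents cannot be told apart here, while both alkyne-bearing compounds lie far from them. Compound 2 holds only a limit of the assay: the limit of > 200000 nM in this assay, at which 2 of the 4 values shown sit.

Going by these compounds, the step between compound 2 and compound 3 cannot be read, and their true values remain unknown. On these data alone, how an amine, a carboxylic acid or a longer alkyl chain at this position would read in this assay stays open.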